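The source may report more compounds than this note shows. Statements on the series, on what has been measured and on what is new or still open speak of the compounds shown alone.

Compound 2 `COc1cc(Oc2cccc(Nc3ccccc3)c2)cc(OC)c1CNC1CC1` carries a cyclopropyl on an amine nitrogen of the shared core. In a functional assay on SW-620 cells (Homo sapiens) for inhibition, read by MTT assay, with a stated time of 72 h (a higher number here means a weaker inhibitor, a lower number a stronger inhibitor), compound 2 gives only a limit, > 20000 nM, because the limit of > 20000 nM in this assay, at which 1 of the 3 values shown sits, is reached. Compound 1 `COc1cc(Oc2cccc(Nc3ccccc3)c2)cc(OC)c1CNCc1ccc(Cl)cc1` gives 6340 nM in this assay, and compound 3 `CNCc1c(OC)cc(Oc2cccc(Nc3ccccc3)c2)cc1OC` gives 15000 nM. Compound 4 `COc1ccc(CNCc2c(OC)cc(Oc3cccc(Nc4ccccc4)c3)cc2OC)cc1` changes the same amine nitrogen again. 4-methoxybenzyl in place of cyclopropyl on an amine nitrogen Two measured steps bear on this: an at least 3.1-fold higher number from compound 1 to compound 2 (0.49 log units; beyond the scatter) shows that removing the 4-chlorobenzyl weakens inhibition, while an at least 1.3-fold lower number from compound 2 to compound 3 (0.12 log units; that floor lies within the scatter) is of uncertain size. A 4-methoxybenzyl is therefore expected to recover much of what compound 1 shows, so for compound 4 the step of an at least 2.8-fold lower number from compound 2 to compound 4 (0.45 log units; beyond the scatter) is expected, downward and beyond the scatter. Compound 4 is estimated at 7000 nM, within a range of 3000 nM to 20000 nM.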

Compound 4, half-maximal inhibitory concentration: 6970 nM
Estimate against measurement, compound 4: 1.0-fold (0.00 log units) above, within the range that was stated.
By their numbers in this assay, from the lowest: compounds 1 and 4 (each within the scatter of the next); then compound 3. At a limit, above all of these: compound 2.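

Methoxy in place of chloro on an aromatic carbon leaves the reading unchanged (a 1.1-fold higher number from compound 1 to compound 4 (0.04 log units; within the scatter)), so 4-methoxybenzyl and 4-chlorobenzyl on the amine nitrogen read alike. The advantage over the small groups therefore holds for a second substituted benzyl, not for 4-chlorobenzyl alone (an at least 2.8-fold lower number from compound 2 to compound 4 (0.45 log units; beyond the scatter); a 2.2-fold lower number from compound 3 to compound 4 (0.33 log units; beyond the scatter)). Compound 2 remains a limit, so its step is only a floor: the limit of > 20000 nM in this assay, at which 1 of the 4 values shown sits.

Going by these compounds, whether an unsubstituted benzyl, a 4-hydroxybenzyl or a longer chain such as phenethyl on this nitrogen reads the same stays open. So does whether any group here moves the number well below that of the two benzyl compounds.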